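Saturating the carboxylic acid side chain of compound 2

This account rests on a few compounds, and the source may have more. Where it says the series, first, only, none or still open, it means among the compounds named here.

In a functional assay on MDA-MB-435S cells (Homo sapiens) for cytotoxicity, read by MTT assay (a higher number here means a weaker inhibitor, a lower number a stronger inhibitor), compound 1 (`COc1ccc(-c2oc3c(CC=C(C)C)c(OC(C)C(=O)O)cc(O)c3c(=O)c2O)cc1`) gives 5700 nM and compound 2 (`COc1ccc(-c2oc3c(CC=C(C)C)c(OC/C=C/C(=O)O)cc(O)c3c(=O)c2O)cc1`) gives 11300 nM. Within the data shown here, these two values lie within the scatter of each other, so compound 2 cannot be separated from the only other measured member of the series.

Compound 3 (`COc1ccc(-c2oc3c(CC=C(C)C)c(OCCCC(=O)O)cc(O)c3c(=O)c2O)cc1`) keeps the shared core and carries 2-carboxyethyl in place of 2-carboxyethenyl on a saturated chain carbon bound to an oxygen on an aromatic ring. Cut one bond further out, this reads 3-carboxyprop-2-en-1-yl to 3-carboxypropyl.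

Among the measured compounds shown here, one measured step bears on this change: a 2.0-fold higher number from compound 1 to compound 2 (0.30 log units; within the scatter). It replaced 1-carboxyethyl with 3-carboxyprop-2-en-1-yl on the same oxygen and did not exceed the scatter. For the measured compounds named here, no measured pair isolates the loss of the chain double bond, so the evidence is thin and the range stays wide. No step beyond the scatter, in either direction, is expected in this assay. The estimated change is a 1.3-fold lower number from compound 2 to compound 3 (0.10 log units; within the scatter). For compound 3, the expected value is 9000 nM, with an estimated range of 3500 nM to 25000 nM.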

Compound 3, half-maximal inhibitory concentration: 12700 nM
Estimate against measurement, compound 3: 1.4-fold (0.15 log units) below; the measured number falls inside the stated range.
By their numbers in this assay, from the lowest: compounds 1, 2 and 3 (each within the scatter of the next, the first and the last beyond it).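

In this assay, the step for loss of the chain double bond is a 1.1-fold higher number from compound 2 to compound 3 (0.05 log units; within the scatter), so 2-carboxyethenyl and 2-carboxyethyl cannot be told apart on a saturated chain carbon bound to an oxygen on an aromatic ring, and the double bond shows no measurable bearing on this read-out in this pair. The series now also holds its first step beyond the scatter, a 2.2-fold higher number from compound 1 to compound 3 (0.35 log units; beyond the scatter), a modest separation of 3-carboxypropyl from 1-carboxyethyl on the oxygen that compound 2, with its unsaturated chain, did not provide. No measurement at hand accounts for either step.

The 1-carboxyethyl and 3-carboxypropyl groups differ in both chain length and branching, so the compounds shown do not say which of the two goes with the modest step; an unbranched carboxymethyl group or a longer chain ending in a carboxylic acid would help to separate them. Going by these compounds, whether the carboxylic acid itself matters on this chain also stays open, a question that a methyl ester or a primary amide in its place would address.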